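Hydroxypropyl pyridone series: carbamate replacing aryloxypropyl ether

The compounds below may be only part of what the source reports. "The series", "measured", "known", "first", "only" and "open" are said of these compounds alone.

Measured so far in a functional assay on PANC-1 cells (Homo sapiens) for inhibition, read by MTT assay, with a stated time of 24 h, tested at 10 uM; a lower number here means less inhibition, a higher number more inhibition at the concentration tested (going by the name of the read-out):
compound 1 `CCOc1cc(=O)n(CCCO)c2c1CC(CC=C(C)C)C(C)(C)C2`, 66.5%
compound 2 `CC(C)=CCC/C(C)=C/COc1cc(=O)n(CCCO)c2c1CC(CC=C(C)C)C(C)(C)C2`, 10.6%
compound 3 `CC(C)=CCC1Cc2c(OCCCOc3ccc(Cl)cc3)cc(=O)n(CCCO)c2CC1(C)C`, 22.7%

Compound 3 is second highest of the three numbers; the nearest step is a number 12.1 percentage points higher from compound 2 to compound 3 (beyond the scatter) and the furthest step is a number 43.8 percentage points lower from compound 1 to compound 3 (beyond the scatter). Compound 4 `CC(C)=CCC1Cc2c(OC(=O)Nc3cccc(F)c3)cc(=O)n(CCCO)c2CC1(C)C` differs from compound 3 as follows: (3-fluorophenyl)carbamoyl in place of 3-(4-chlorophenoxy)propyl on an oxygen on an aromatic ring. Going by the values given here, the steps that bear on the same oxygen are a number 55.9 percentage points lower from compound 1 to compound 2 (beyond the scatter) and a number 43.8 percentage points lower from compound 1 to compound 3 (beyond the scatter), both large drops; a number 12.1 percentage points higher from compound 2 to compound 3 (beyond the scatter) shows a modest recovery. Among the compounds with values here, no measured step introduces a carbamoyl group, so the direction is uncertain. A step of a number 5.3 percentage points higher from compound 3 to compound 4 (within the scatter) is expected, staying near compound 3. Compound 4 is estimated at 28%, within 8% to 55%.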

Compound 4, a percentage reported as inhibition, at one concentration (the size of the read-out at that concentration, not a potency): 66.1%
Beside the measured number, compound 4's estimate is 38.1 percentage points below it, and the stated range ends below it.
By their numbers in this assay, from the lowest: compound 2; then compound 3; then compounds 4 and 1 (each within the scatter of the next).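

On the oxygen on an aromatic ring, in this assay, (3-fluorophenyl)carbamoyl gives a large rise over 3-(4-chlorophenoxy)propyl, with a number 43.4 percentage points higher from compound 3 to compound 4 (beyond the scatter), and over 3,7-dimethylocta-2,6-dien-1-yl, with a number 55.5 percentage points higher from compound 2 to compound 4 (beyond the scatter). Against ethyl there is a number 0.4 percentage points lower from compound 1 to compound 4 (within the scatter), so a group of 10 heavy atoms on this oxygen can stand level with ethyl, and the earlier drops do not hold for every larger group. No evidence here accounts for the gap between the carbamoyl and the ether groups. Still open, from the compounds shown here alone, is whether the carbamoyl link or the 3-fluorophenyl ring carries the result; a benzoyl group or a carbamoyl with a methylated nitrogen on the same oxygen would test this.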